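Solubility notes: aryl swap at the nitrile-flanked position

The source may report more compounds than this note shows. Statements on the series, on what has been measured and on what is new or still open speak of the compounds shown alone.

Measured compounds:
- compound 1 `CCc1ccc(-c2nc3c(c(C)nn3-c3ccccc3)c(-c3ccccc3I)c2C#N)cc1`: 8500 nM
- compound 2 `CCc1ccc(-c2nc3c(c(C)nn3-c3ccccc3)c(-c3ccccc3Cl)c2C#N)cc1`: 1700 nM
- compound 3 `Cc1cccc(-c2nc3c(c(C)nn3-c3ccccc3)c(-c3ccccc3O)c2C#N)c1`: 42000 nM

In a physicochemical assay for solubility, read by spectrophotometry, in phosphate buffer, with a stated time of 18 h, at pH 7.4 (on this read-out higher numbers stand for higher solubility and lower numbers for lower solubility), compound 3 stands highest of the three numbers. Its nearest neighbour is compound 1, and the gap to compound 2 is wider still; both gaps lie beyond the scatter. Among the measured compounds shown here, the only single-point step within the measured set is a 5.0-fold lower number from compound 1 to compound 2 (0.70 log units; beyond the scatter), a halogen exchange on the ortho-substituted phenyl ring.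

Compound 4 `Cc1nn(-c2ccccc2)c2nc(-c3ccc4c(c3)OCCO4)c(C#N)c(-c3ccccc3O)c12` is the next compound for this assay. It differs from compound 3 at the aromatic carbon next to the ring nitrogen of the shared core, ortho to the cyano group: 2,3-dihydro-1,4-benzodioxin-6-yl in place of 3-methylphenyl on an aromatic carbon.

For the measured compounds named here, no measured step touches this position or this kind of exchange, so the halogen step between compound 1 and compound 2 gives no direct guide. The 2-hydroxyphenyl group of compound 3 is kept in compound 4, and compound 3 gives 42000 nM with it. Without a comparable step, the expectation is a number close to that of compound 3, with a wide range: compound 4 is expected at 40000 nM, between 13000 nM and 130000 nM, which means an expected step of a 1.1-fold lower number from compound 3 to compound 4 (0.02 log units; within the scatter), not clearly beyond the scatter in either direction.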

Compound 4, solubility: 11000 nM
Compound 4: the middle estimate sits 3.6-fold (0.56 log units) above what was measured; the whole stated range lies above it.
By their numbers in this assay, from the lowest: compound 2; then compounds 1 and 4 (each within the scatter of the next); then compound 3.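

In this assay, the aromatic carbon next to the ring nitrogen and ortho to a cyano group proves able to shift the read-out: 2,3-dihydro-1,4-benzodioxin-6-yl in place of 3-methylphenyl gives a 3.8-fold lower number from compound 3 to compound 4 (0.58 log units; beyond the scatter). Among the compounds shown here, the earlier single-place step covered only chloro in place of iodo at another place, so this is the first reading at this position, and in this one pair the entering group, with 10 heavy atoms and 2 hydrogen-bond acceptors against 7 and 0, goes with the lower number. No measured evidence on the compounds accounts for the step, so its origin stays unassigned.

The compounds shown leave open whether the step follows the non-aromatic ring itself or its two oxygen atoms, which a phenyl group carrying a single methoxy group or a dimethylamino group at this place could help to separate. They also leave open whether a carboxylic acid on this phenyl ring would move the number the other way, and whether the same exchange gives a similar step with iodo or chloro on the other aryl group.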